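The source may hold more compounds than are shown below. What is called first, only, known or untested is meant among the compounds shown, and "the series" means these compounds.

In an ADME assay on the whole organism (strain 129/SvEvBrd x C57BL/6) for metabolic stability, with Mus musculus as the target (on this read-out higher numbers stand for a longer-lived compound and lower numbers for a shorter-lived compound), compound 1 (`CC(=O)c1nc([C@@H](O)[C@H](O)[C@H](O)CO)c(C)[nH]1`) gives 6.2 h and compound 2 (`CCc1[nH]c(C(C)=O)nc1[C@@H](O)[C@H](O)[C@H](O)CO`) gives 2.8 h. Compound 3 (`CC(O)c1nc([C@@H](O)[C@H](O)[C@H](O)CO)c[nH]1`) gives 4.4 h, which lies within the scatter of both. Compound 4 (`OC[C@@H](O)[C@@H](O)[C@H](O)c1c[nH]c(-c2ncccn2)n1`) carries pyrimidin-2-yl in place of 1-hydroxyethyl on an aromatic carbon. Within the data shown here, only one measured step is available, and it bears on this change only indirectly: a 2.2-fold lower number from compound 1 to compound 2 (0.35 log units; beyond the scatter). That modest step lies at a different place, on a saturated chain carbon, so it suggests a size of step in this small set but gives no direction for the new group. Among the measured compounds shown here, no measured compound carries an aromatic ring at the changed position. The expectation therefore rests on compound 3 at 4.4 h, and no step beyond the scatter is expected, though the size of the exchange keeps the range wide. The expected step is a 1.3-fold lower number from compound 3 to compound 4 (0.10 log units; within the scatter). For compound 4 the estimated half-life is 3.5 h, with an expected range of 1.2 h to 10 h.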

Compound 4, half-life: 2.4 h
Beside the measured number, compound 4's estimate is 1.5-fold (0.16 log units) above it, and the stated range covers the measured number.
By their numbers in this assay, from the lowest: compounds 4, 2, 3 and 1 (each within the scatter of the next, the first and the last beyond it).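

In this assay, placing pyrimidin-2-yl where 1-hydroxyethyl stood gives a 1.8-fold lower number from compound 3 to compound 4 (0.26 log units; within the scatter), a step that stays within the scatter. Among these compounds, this is the first view of a six-membered aromatic ring on this aromatic carbon between two ring nitrogen atoms, and it shows that even this larger exchange, with a ring entering where no ring left, produces no step beyond the scatter in this read-out. Nothing available explains the result, and the half-life alone gives no mechanism for it.

The compounds shown leave open whether phenyl or pyridin-2-yl would read like pyrimidin-2-yl, and whether an amine or a carboxylic acid at this place would produce a step beyond the scatter. They also leave open how pyrimidin-2-yl would read on the core of compound 1, which carries a methyl group.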